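A few compounds are considered here, and "the series" means these few. Any claim that something is new, unique, unknown or untested is made for them only; others in the source may bear on it.

Measured compounds and their values:

Compound 1 `COc1c(OCCCCN2CCN(C)CC2)cc(O)c2c(=O)cc(-c3ccc(Cl)cc3)oc12`: 2090 nM
Compound 2 `COc1c(OCCCCN2CCN(C)CC2)cc(O)c2c(=O)cc(-c3ccc(C(F)(F)F)cc3)oc12`: 4990 nM
Compound 3 `CCN(CC)CCCOc1c(OCc2ccccc2)cc(O)c2c(=O)cc(-c3ccccc3)oc12`: 4900 nM

All three were tested in a functional assay on B16 cells (Mus musculus) for cytotoxicity, read by MTT assay, with a stated time of 72 h; on this read-out higher numbers stand for weaker inhibition and lower numbers for stronger inhibition. Compound 3 gives 4900 nM, the second highest of the three numbers. Compound 2, which gives 4990 nM, sits within the scatter of compound 3, so the two cannot be told apart. Compound 1 gives 2090 nM, a lower number than compound 3 by a margin that lies beyond the scatter.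

Compound 4 `O=c1cc(-c2ccccc2)oc2c(OCCCCN3CCCC3)c(OCc3ccccc3)cc(O)c12` is not yet measured. It differs from compound 3 in one place: (pyrrolidin-1-yl)methyl in place of diethylamino on a saturated chain carbon, three bonds along the chain from an oxygen on an aromatic ring. Among the compounds with values here, the only measured step with a single change is a 2.4-fold higher number from compound 1 to compound 2 (0.38 log units; beyond the scatter), and that step concerns the aromatic substituent, not the amine on the chain. Within the data shown here, no measured step speaks to the change from compound 3 to compound 4, and the two amines are alike in what is counted. A step within the scatter is therefore expected in this assay, in either direction. This expectation amounts to a 1.1-fold lower number from compound 3 to compound 4 (0.04 log units; within the scatter). Compound 4 is thus estimated to give 4500 nM, within a range from 2000 nM to 10000 nM.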

Compound 4, half-maximal inhibitory concentration: 3210 nM
The estimate for compound 4 lay 1.4-fold (0.15 log units) above the measured number; the measured number falls inside the stated range.
By their numbers in this assay, from the lowest: compounds 1, 4, 3 and 2 (each within the scatter of the next, the first and the last beyond it).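

In this assay, moving from a 3-(diethylamino)propyl chain to a 4-(pyrrolidin-1-yl)butyl chain gives a 1.5-fold lower number from compound 3 to compound 4 (0.18 log units; within the scatter). Within the data shown here, this is the only measured step at this place on the chain, and it shows that an open diethylamino end and a five-membered ring with one more chain carbon cannot be told apart in this assay, even though the entering group contains a ring and the leaving group does not. No outside measurement bears on this result, so nothing can be said about what lies behind it.

On these data alone, the step changes the amine and the chain together, so the part played by each stays open; a 3-(pyrrolidin-1-yl)propyl chain would separate the two. As far as these compounds go, how a piperidine or a morpholine would read on the same chain also remains open.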